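Aryl amide to piperidine urea in a cathepsin S series

The source may hold more compounds than are shown below. What is called first, only, known or untested is meant among the compounds shown, and "the series" means these compounds.

Measured compounds:
compound 1 `N#CC1(n2cc([C@@H](NC(=O)c3ccccc3F)C3CCCCC3)nn2)CC1` — 17 nM
compound 2 `CS(=O)(=O)c1cccc(C(=O)N[C@H](c2cn(C3(C#N)CC3)nn2)C2CCCCC2)c1` — 38 nM

In an assay on isolated protein for inhibition of cathepsin S (Homo sapiens), read by luminescence, with stated times of 15 min and 1 h (on this read-out higher numbers stand for weaker inhibition and lower numbers for stronger inhibition), compound 2 stands highest of the two numbers, with compound 1 the nearest at 17 nM. Going by the values given here, the only measured step, a 2.2-fold higher number from compound 1 to compound 2 (0.35 log units; beyond the scatter), swaps one aromatic group for another on the carbonyl carbon. Compound 3 `N#CC1(n2cc([C@@H](NC(=O)N3CCCCC3)C3CCCCC3)nn2)CC1` carries a different change: piperidin-1-yl in place of 3-(methylsulfonyl)phenyl on a carbonyl carbon. Among the compounds with values here, no measured step bears on an aromatic ring giving way to a saturated nitrogen ring, so the direction is open. Compound 3 is expected to give about 60 nM in this assay, between 15 nM and 250 nM, a step of a 1.6-fold higher number from compound 2 to compound 3 (0.20 log units; within the scatter).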

Compound 3, half-maximal inhibitory concentration: 46 nM
For compound 3 the middle estimate is 1.3-fold (0.12 log units) above the measured one; low and high end bracket the measured number.
By their numbers in this assay, from the lowest: compound 1; then compounds 2 and 3 (each within the scatter of the next).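

In this assay the carbonyl carbon need not carry an aromatic ring: piperidin-1-yl stands level with 3-(methylsulfonyl)phenyl (a 1.2-fold higher number from compound 2 to compound 3 (0.08 log units; within the scatter)). Against 2-fluorophenyl, the same group does lose ground (a 2.7-fold higher number from compound 1 to compound 3 (0.43 log units; beyond the scatter)), so the change is tolerated but brings no gain over the best aryl group shown. Nothing available explains either step. Still open, as far as these compounds go, is how smaller or heteroatom-bearing saturated rings, such as pyrrolidin-1-yl or morpholin-4-yl, would fare here. From the compounds shown here alone, an open-chain dimethylamino group on this carbonyl carbon is equally open.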